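The compounds below may be only part of what the source reports. "The series", "measured", "known", "first", "only" and "open" are said of these compounds alone.

Measured in a functional assay on HeLa cells (Homo sapiens) for cytotoxicity, read by MTT assay, with a stated time of 24 h (a higher number here means a weaker inhibitor, a lower number a stronger inhibitor), where each value is a limit and not a number:

Compound 1 `CCCCCc1cc2ccccc2nc1-c1cn(-c2ccc(F)cc2)nn1`: > 100 ug/mL
Compound 2 `CCc1cc2ccccc2nc1-c1cn(-c2ccc(F)cc2)nn1`: > 100 ug/mL

Compound 2, the starting point here, gives > 100 ug/mL. This is a limit of the assay, so it gives no exact position for compound 2. The same is true of compound 1, and both values sit at one shared limit: the limit of > 100 ug/mL in this assay, at which 2 of the 2 values shown sit.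

Compound 3 `CCCCc1cc2ccccc2nc1-c1cn(-c2ccc(F)cc2)nn1` keeps the shared core and changes only the chain: ethyl in place of hydrogen on a saturated chain carbon, two bonds along the chain from an aromatic carbon. In words, ethyl replaces hydrogen on a saturated chain carbon, two bonds along the chain from an aromatic carbon. Within the data shown here, one measured step bears on this change, at the same place but in the opposite direction and with propyl rather than ethyl: a step that the two limits leave unreadable from compound 1 to compound 2. Its size cannot be read, but neither end of that step gave a number. No clear change is therefore expected, and compound 3 will probably also be reported only as a limit. The expected step, a step that the limit leaves unreadable from compound 2 to compound 3, is a rough estimate that stays within the usual scatter.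

For compound 3 the estimated value is 130 ug/mL, with an expected range of 70 ug/mL to 300 ug/mL.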

Compound 3, half-maximal inhibitory concentration: > 100 ug/mL
Compound 3: a limit, no number; the forecaster's own chance of this, stated with the estimate: 85%; the middle value lies beyond the limit too.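

In this assay compound 3 gives > 100 ug/mL as a limit and not a number. Among these compounds, no step among compound 1, compound 2 and compound 3 can be read, as all three sit together: the limit of > 100 ug/mL in this assay, at which 3 of the 3 values shown sit. The compounds shown leave open whether changing the chain alters the effect on these cells at all.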